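Chloro for methoxy on the pendant phenyl of compound 3

A few compounds are considered here, and "the series" means these few. Any claim that something is new, unique, unknown or untested is made for them only; others in the source may bear on it.

The series holds a shared core with a varied aryl arm: compound 1 `c1ccc(-c2nnc(-c3c[nH]c4ccccc34)o2)cc1`, compound 2 `c1ccc(Cc2nnc(-c3c[nH]c4ccccc34)o2)cc1` and compound 3 `COc1ccc(-c2nnc(-c3c[nH]c4ccccc34)o2)cc1` have been measured, compound 4 `Clc1ccc(-c2nnc(-c3c[nH]c4ccccc34)o2)cc1` has not. In a functional assay on PC-3 cells (Homo sapiens) for cytotoxicity, read by MTT assay (on this read-out lower numbers stand for stronger inhibition and higher numbers for weaker inhibition), compound 1 gives > 1000000 nM, which is a limit of the assay and not a number. In this assay compound 2 gives > 1000000 nM, again only a limit. Compound 3 likewise gives > 1000000 nM, a limit. Compound 3 therefore stands nowhere distinguishable on the numbers shown; all three values sit together at the limit of > 1000000 nM in this assay, at which 3 of the 3 values shown sit.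

The change from compound 3 to compound 4 is chloro in place of methoxy on an aromatic carbon. The measured steps that bear on substitution at this arm are a step that the two limits leave unreadable from compound 1 to compound 2 and a step that the two limits leave unreadable from compound 1 to compound 3, and neither can be sized, since both ends are limits. Among the measured compounds shown here, nothing measured so far separates any member of the series from the others, so no step beyond the scatter is expected in this assay from the exchange of methoxy for chloro; the expected step of a number no higher from compound 3 to compound 4 (the limit leaves the size open) is read as none.

Compound 4 is accordingly estimated at 1000000 nM, within 200000 nM to 5000000 nM, with a strong likelihood that this assay again reports only a limit.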

Compound 4, half-maximal inhibitory concentration: 41600 nM
Beside the measured number, compound 4's estimate is 24-fold (1.38 log units) above it; the measured number lies below the stated range.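

In this assay, among the compounds shown here, chloro in place of methoxy on this aromatic carbon, para to a large group, gives an at least 24-fold lower number from compound 3 to compound 4 (1.38 log units; beyond the scatter), so a change at this position can move the read-out, which the earlier compounds could not show, their steps among themselves being unreadable. Chloro in place of hydrogen on the same carbon gives an at least 24-fold lower number from compound 1 to compound 4 (1.38 log units; beyond the scatter), and 4-chlorophenyl in place of benzyl gives an at least 24-fold lower number from compound 2 to compound 4 (1.38 log units; beyond the scatter), so the separation holds against all three other arms and not against methoxy alone. Compound 4 is the only member of the series with a value that is a number, while the other three values are limits: the limit of > 1000000 nM in this assay, at which 3 of the 4 values shown sit.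

From the compounds shown here alone, the true size of each of these steps stays open, as one end of each is a limit. Whether fluoro, bromo, a nitrile or an amine on this carbon would also give a value that is a number is open, and so is whether chloro on another carbon of the ring would do the same.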